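Ring size at the ester and a thiophene core

The compounds below may be only part of what the source reports. "The series", "measured", "known", "first", "only" and "open" are said of these compounds alone.

Measured so far in an assay on membranes from HEK293 cells for displacement of a labelled ligand from adenosine receptor A2b (Homo sapiens), read by scintillation counting, with a stated time of 30 min; a higher number here means a weaker inhibitor, a lower number a stronger inhibitor:
compound 1, `CC1=C(C(=O)OC2CCC2)C(c2ccoc2)NC(=O)N1`: 307 nM
compound 2, `CC1=C(C(=O)OC2CCCC2)C(c2ccoc2)NC(=O)N1`: 1010 nM
compound 3, `CC1=C(C(=O)OC2CCC2)C(c2ccsc2)NC(=O)N1`: 405 nM

Within this set one change has already been measured: cyclopentyl in place of cyclobutyl on an oxygen next to a carbonyl group. This gave a 3.3-fold higher number from compound 1 to compound 2 (0.52 log units; beyond the scatter). Compound 3 has a different core, described as thiophen-3-yl in place of furan-3-yl on a saturated ring carbon, and the pair shows a 1.3-fold higher number from compound 1 to compound 3 (0.12 log units; within the scatter), so the two cores give much the same number in this assay.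

Compound 4, `CC1=C(C(=O)OC2CCCC2)C(c2ccsc2)NC(=O)N1`, has not yet been measured. It differs from compound 3 by cyclopentyl in place of cyclobutyl on an oxygen next to a carbonyl group, the same change at the same place as between compound 1 and compound 2. Because the matching change gave a 3.3-fold higher number from compound 1 to compound 2 (0.52 log units; beyond the scatter), compound 4 is expected to show a 3.1-fold higher number from compound 3 to compound 4 (0.49 log units; beyond the scatter). The estimate for compound 4 in this assay is therefore 1250 nM, with a likely range from 500 nM to 3200 nM.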

Compound 4, inhibition constant: 659 nM
Compound 4: middle estimate off by 1.9-fold (0.28 log units), on the high side; low and high end bracket the measured number.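

In this assay, cyclopentyl in place of cyclobutyl on the second core gives a 1.6-fold higher number from compound 3 to compound 4 (0.21 log units; within the scatter), and this step does not differ beyond the scatter from the same change on the first core: the same change on two cores in this assay, a 3.3-fold higher number (0.52 log units; beyond the scatter) from compound 1 to compound 2 and a 1.6-fold higher number (0.21 log units; within the scatter) from compound 3 to compound 4, 2.0-fold (0.31 log units) apart, within the scatter of two such steps. Thiophen-3-yl in place of furan-3-yl with cyclopentyl on the ester gives a 1.5-fold lower number from compound 2 to compound 4 (0.19 log units; within the scatter), which also agrees with the earlier step for that change: the same change on two cores in this assay, a 1.3-fold higher number (0.12 log units; within the scatter) from compound 1 to compound 3 and a 1.5-fold lower number (0.19 log units; within the scatter) from compound 2 to compound 4, 2.0-fold (0.31 log units) apart, within the scatter of two such steps. Across these four compounds, each change can be carried from one core to the other within the scatter, but this does not establish a real difference between compound 3 and compound 4, or that the two steps for the ring change are the same size.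

Going by these compounds, a cyclohexyl ring or an open chain such as n-butyl on the oxygen next to the carbonyl group remains open. So does whether a phenyl group on the saturated ring carbon would follow the same pattern.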